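Working notes: the step from compound 3 to compound 4

The source may hold more compounds than are shown below. What is called first, only, known or untested is meant among the compounds shown, and "the series" means these compounds.

In a functional assay on MCF7 cells (Homo sapiens) for inhibition, read by MTT assay, with a stated time of 72 h (a lower number here means a stronger inhibitor, a higher number a weaker inhibitor), compound 3 `COc1cc(NC(C)CCCNC(=O)Nc2ccc(C(F)(F)F)cc2)c2ncccc2c1` gives 1900 nM. Within the data shown here, compound 1 `COc1cc(NC(C)CCCNC(=O)Nc2ccc(Br)cc2)c2ncccc2c1` gives 2600 nM, and the only measured step between matched compounds, a 1.4-fold lower number from compound 1 to compound 3 (0.14 log units; within the scatter), lies within the scatter. Compound 2 `COc1cc(NC(C)CCCNC(=O)NNC(=O)Nc2ccc(C(F)(F)F)cc2)c2ncccc2c1` gives 100 nM, a number well beyond the scatter under that of compound 3.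

Compound 4 `COc1cc(NC(C)CCCNC(=O)NNC(=O)Nc2ccc(O)cc2)c2ncccc2c1` follows from ((4-hydroxyphenyl)carbamoyl)amino in place of 4-(trifluoromethyl)phenyl on an amide-type nitrogen, with ((4-hydroxyphenyl)carbamoyl)amino in place of 4-(trifluoromethyl)phenyl on an amide-type nitrogen. Compound 4 differs from compound 2 only in bearing hydroxy rather than trifluoromethyl on the terminal ring. Compound 2 at 100 nM is therefore the closest guide. Among the measured compounds shown here, the measured step of a 1.4-fold lower number from compound 1 to compound 3 (0.14 log units; within the scatter) covers only bromo and trifluoromethyl, and no hydroxy compound has been measured, so a wide margin is kept on the high side. In this assay a move to a lower number, beyond the scatter, is expected, namely a 4.8-fold lower number from compound 3 to compound 4 (0.68 log units; beyond the scatter). The estimate for compound 4 is 400 nM, with an expected range of 90 nM to 2000 nM.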

Compound 4, half-maximal inhibitory concentration: 2600 nM
Beside the measured number, compound 4's estimate is 6.5-fold (0.81 log units) below it, and the stated range ends below it.
By their numbers in this assay, from the lowest: compound 2; then compounds 3, 1 and 4 (each within the scatter of the next).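

In this assay, the longer compounds prove sensitive to the group on the aromatic carbon of the terminal ring: hydroxy in place of trifluoromethyl gives a 26-fold higher number from compound 2 to compound 4 (1.41 log units; beyond the scatter) and removes the advantage seen with compound 2. On the amide-type nitrogen, ((4-hydroxyphenyl)carbamoyl)amino gives a 1.4-fold higher number from compound 3 to compound 4 (0.14 log units; within the scatter) in place of 4-(trifluoromethyl)phenyl and no change at the digits printed from compound 1 to compound 4 (within the scatter) in place of 4-bromophenyl, so this longer group brings no gain by itself and the low number of compound 2 requires its trifluoromethyl as well. No measurement at hand explains the difference between hydroxy and trifluoromethyl here.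

Among these compounds, still open is whether trifluoromethyl is the only group on that aromatic carbon that keeps the longer compounds at a low number. A nitrile, an amine or a carboxylic acid there would help to show how narrow this requirement is.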